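Acyclic purine series: carbamate to pivalate on the side chain

The source may report more compounds than this note shows. Statements on the series, on what has been measured and on what is new or still open speak of the compounds shown alone.

Working notes on a small set tested in a functional assay for inhibition, with Rattus norvegicus as the target; on this read-out lower numbers stand for stronger inhibition and higher numbers for weaker inhibition. Compound 1 `CNc1nc(Cl)nc2c1ncn2CC(COC(=O)Nc1ccccc1)COP(=O)(O)O` gives 2500 nM, the lowest number of the three measured. Compound 2 `CNc1nc(Cl)nc2c1ncn2CC(COC(=O)c1ccccc1)COC(=O)c1ccccc1` gives 5100 nM, and compound 3 `CNc1nc(Cl)nc2c1ncn2CC(COC(=O)CCC(=O)O)COC(=O)CCC(=O)O` gives 18000 nM; both lie beyond the scatter from compound 1, but neither differs from compound 1 in only one place, so no single step can be read from them. Compound 4 `CNc1nc(Cl)nc2c1ncn2CC(COC(=O)C(C)(C)C)COP(=O)(O)O` is not yet measured. It differs from compound 1 in one place: tert-butyl in place of anilino on a carbonyl carbon. Among the measured compounds shown here, no measured pair isolates this change, so its direction has to be judged without precedent. Starting from compound 1 at 2500 nM, a step of moderate size in this assay is expected, with a somewhat higher number, meaning weaker inhibition, considered slightly more likely than a lower one, though a result within the scatter would not surprise. Compound 4 is therefore expected to give 3500 nM, within a range of 1200 nM to 10000 nM. The step this estimate implies is expected to be a 1.4-fold higher number from compound 1 to compound 4 (0.15 log units; within the scatter).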

Compound 4, inhibition constant: 29000 nM
Beside the measured number, compound 4's estimate is 8.3-fold (0.92 log units) below it; measured number outside the range, above it.
By their numbers in this assay, from the lowest: compound 1; then compound 2; then compounds 3 and 4 (each within the scatter of the next).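

In this assay, among the compounds shown here, tert-butyl in place of anilino on this carbonyl carbon gives a 12-fold higher number from compound 1 to compound 4 (1.06 log units; beyond the scatter), the first step that isolates a single change, and a large one. The position is therefore sensitive to the group it carries, and of this pair the anilino group gives the stronger inhibition. No measurement available here accounts for the size or direction of this step.

Anilino and tert-butyl differ at once in the aromatic ring, the hydrogen-bond donor and the heavy-atom count, so this single pair cannot separate those differences. A cyclohexylamino group would keep the nitrogen without the aromatic ring, and a benzyl group on the same carbonyl carbon would keep an aromatic ring without the nitrogen, so these two would begin to divide the step.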